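Benzoyl in place of acetyl on the ring nitrogen

The source may report more compounds than this note shows. Statements on the series, on what has been measured and on what is new or still open speak of the compounds shown alone.

Compound 2 `CC(=O)N1c2ccccc2CCC1C(=O)Nc1cc(C(F)(F)F)cc(C(F)(F)F)c1` is reported in a functional assay on PC-3 cells (Homo sapiens) for cytotoxicity, read by sulforhodamine B assay, with a stated time of 72 h (on this read-out lower numbers stand for stronger inhibition of growth and higher numbers for weaker inhibition of growth), only as a limit: compound 2 gives > 70000 nM, which is where (the limit of > 70000 nM in this assay, at which 1 of the 3 values shown sits). Compound 1 `O=C(Nc1ccccc1O)C1CCc2ccccc2N1C(=O)c1ccc(Cl)cc1` gives 25100 nM in this assay. Compound 3 `CCCCCCCCC(=O)N1c2ccccc2CCC1C(=O)Nc1ccccc1C(F)(F)F` gives 4320 nM in this assay. Compound 4 `O=C(Nc1cc(C(F)(F)F)cc(C(F)(F)F)c1)C1CCc2ccccc2N1C(=O)c1ccccc1` carries phenyl in place of methyl on a carbonyl carbon, phenyl in place of methyl on a carbonyl carbon, and has not yet been measured. For the measured compounds named here, since compound 2 sits at a limit, the step of an at least 2.3-fold lower number from compound 2 to compound 4 (0.36 log units; beyond the scatter) can only be expected to point towards stronger inhibition of growth or to stay at the limit, with no measured step of this kind to set its size. Compound 4 is estimated at 30000 nM, in a range from 8000 nM to 70000 nM.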

Compound 4, concentration for 50% growth inhibition: 3500 nM
Estimate against measurement, compound 4: 8.6-fold (0.93 log units) above; measured number outside the range, below it.
By their numbers in this assay, from the lowest: compounds 4 and 3 (each within the scatter of the next); then compound 1. At a limit, above all of these: compound 2.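

In this assay, for the compounds shown here, the change from acetyl to benzoyl brings an at least 20-fold lower number from compound 2 to compound 4 (1.30 log units; beyond the scatter), the first sign that the group on this carbonyl carbon can move the read-out by a wide margin. Compound 2 is reported only as a limit, so this step gives a minimum size and not an exact one: the limit of > 70000 nM in this assay, at which 1 of the 4 values shown sits.

The compounds shown leave open whether the aromatic ring itself matters, a question that cyclohexyl on the same carbonyl carbon would address. They also leave open how an amine or a carboxylic acid on the phenyl would read.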